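This account rests on a few compounds, and the source may have more. Where it says the series, first, only, none or still open, it means among the compounds named here.

Compound 1 `O=C(Nc1ccccc1)Nc1cccc(CNc2nccnc2Cl)c1` is the starting point of this comparison. Among the measured compounds shown here, in a functional assay on HepG2 cells (Homo sapiens) for antiproliferative activity, read by MTT assay, with a stated time of 48 h (a lower number here means a stronger inhibitor, a higher number a weaker inhibitor), compound 1 gives 15600 nM, the highest of the three numbers measured so far. Compound 2 `Cc1ccc(NC(=O)Nc2cccc(CNc3nccnc3Cl)c2)cc1Cl` gives 11300 nM, and the step of a 1.4-fold lower number from compound 1 to compound 2 (0.14 log units; within the scatter) lies within the scatter, so no real change can be claimed there. Compound 3 `O=C(Nc1cccc(CNc2nccnc2Cl)c1)Nc1cccc(C(F)(F)F)c1` gives 6210 nM, and the step of a 2.5-fold lower number from compound 1 to compound 3 (0.40 log units; beyond the scatter) is modest but beyond the scatter. Compound 4 `O=C(Nc1ccc(C(F)(F)F)cc1)Nc1cccc(CNc2nccnc2Cl)c1` has not yet been measured in this assay. It differs from compound 1 in one place: trifluoromethyl in place of hydrogen on an aromatic carbon. For the measured compounds named here, only one measured step bears on this change, the one from compound 1 to compound 3, where the same kind of group entered in place of hydrogen on an aromatic carbon of the same ring, and it lowered the number modestly. A downward step of similar size is therefore expected from compound 1 to compound 4 in this assay, with a fair chance that it stays within the scatter. Compound 4 is estimated to give 7500 nM, with a range from 3500 nM to 16000 nM, which is expected to mean a step of a 2.1-fold lower number from compound 1 to compound 4 (0.32 log units; beyond the scatter).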

Compound 4, half-maximal inhibitory concentration: 5050 nM
The estimate for compound 4 lay 1.5-fold (0.17 log units) above the measured number; measured number inside the range.
By their numbers in this assay, from the lowest: compounds 4, 3, 2 and 1 (each within the scatter of the next, the first and the last beyond it).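

In this assay trifluoromethyl para to a large group also lowers the number, with a 3.1-fold lower number from compound 1 to compound 4 (0.49 log units; beyond the scatter), so the modest drop seen with compound 3 is not tied to a single carbon of this ring. Compound 3 gives 6210 nM and compound 4 gives 5050 nM, values within the scatter of each other, so these two compounds show no preference between the two carbons. Nothing shown here accounts for the drop with this group.

The compounds shown leave open whether a methoxy group or a carboxylic acid in this same place would move the number in the same way, which would show how far the result depends on trifluoromethyl itself. They also leave open whether two trifluoromethyl groups on this ring would lower it further.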